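The source may report more compounds than this note shows. Statements on the series, on what has been measured and on what is new or still open speak of the compounds shown alone.

Measured so far in an assay on HeLa cells for inhibition of Indoleamine 2,3-dioxygenase 1 (Homo sapiens), with stated times of 1 h and 18 h; a lower number here means a stronger inhibitor, a higher number a weaker inhibitor:
compound 1 `Cc1ccc(NC(=O)Nc2cc(-c3ccccc3C(=O)O)ccc2Nc2ccccc2C(C)(C)C)cc1` — 600 nM
compound 2 `Cc1ccc(NC(=O)Nc2cc(-c3ccccc3C(=O)O)ccc2N(CC(C)C)C(C)C)cc1` — 42 nM

Compound 2 stands at the lowest of the two numbers in this assay; its nearest neighbour is compound 1, and the step runs a 14-fold lower number from compound 1 to compound 2 (1.15 log units; beyond the scatter). Compound 3 `Cc1ccc(NC(=O)Nc2cc(-c3ccccc3C(=O)O)ccc2N(CC2CC2)CC2CC2)cc1` differs from compound 2 in one place: bis(cyclopropylmethyl)amino in place of isobutyl(isopropyl)amino on an aromatic carbon. For the measured compounds named here, the only measured step, a 14-fold lower number from compound 1 to compound 2 (1.15 log units; beyond the scatter), replaces a (2-(tert-butyl)phenyl)amino group with an isobutyl(isopropyl)amino group, whereas the change to compound 3 exchanges one dialkylamino group for another of nearly the same size. That step therefore bears only loosely on the new one, and no shift beyond the scatter is expected in either direction. Compound 3 is expected to show a 1.1-fold higher number from compound 2 to compound 3 (0.03 log units; within the scatter) relative to compound 2. Compound 3 is estimated at 45 nM in this assay, with a range from 15 nM to 130 nM.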

Compound 3, half-maximal inhibitory concentration: 348 nM
Compound 3: middle estimate off by 7.7-fold (0.89 log units), on the low side; measured number above the stated range.
By their numbers in this assay, from the lowest: compound 2; then compounds 3 and 1 (each within the scatter of the next).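

In this assay this position, para to a 2-carboxyphenyl group, proves sensitive even to an exchange between two dialkylamino groups: bis(cyclopropylmethyl)amino in place of isobutyl(isopropyl)amino gives an 8.3-fold higher number from compound 2 to compound 3 (0.92 log units; beyond the scatter) in the assay. Against the (2-(tert-butyl)phenyl)amino group, the same bis(cyclopropylmethyl)amino group gives a 1.7-fold lower number from compound 1 to compound 3 (0.24 log units; within the scatter) and so does not separate from it, which shows that a dialkylamino group at this place does not by itself bring the low number of compound 2. Nothing measured here explains the difference between these two amino groups.

The compounds shown leave open whether the three-membered rings or the loss of the isopropyl and isobutyl groups drives the step. An isopropyl(cyclopropylmethyl)amino or a diisobutylamino group at this place would separate the two.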